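Ring-nitrogen substituent change in the diaryl thioether series

This account rests on a few compounds, and the source may have more. Where it says the series, first, only, none or still open, it means among the compounds named here.

Compound 2 `O=C(c1ccc(F)cc1)N1CCC(NCCSC(c2ccc(F)cc2)c2ccc(F)cc2)CC1` holds the lowest number of the three measured: in an assay on membranes from striatum (strain Sprague-Dawley) for displacement of a labelled ligand from sodium-dependent dopamine transporter (Rattus norvegicus), read by scintillation counting, with a stated time of 120 min (on this read-out lower numbers stand for stronger inhibition and higher numbers for weaker inhibition), compound 2 gives 7.04 nM. Compound 1 `[O-][S+](CCNC1CCN(Cc2ccc(F)cc2)CC1)C(c1ccc(F)cc1)c1ccc(F)cc1` gives 50.6 nM, and compound 3 `O=C(c1ccc(F)cc1)N1CCC(NCC[S+]([O-])C(c2ccc(F)cc2)c2ccc(F)cc2)CC1` gives 77.2 nM; both gaps from compound 2 lie beyond the scatter. Compound 4 `CC(C)(C)CN1CCC(NCCSC(c2ccc(F)cc2)c2ccc(F)cc2)CC1` is not yet measured; its change from compound 2 is neopentyl in place of (4-fluorophenyl)carbonyl on an amine nitrogen in a ring. Going by the values given here, one measured step touches the same ring nitrogen: a 1.5-fold higher number from compound 1 to compound 3 (0.18 log units; within the scatter). Neopentyl is neither of those groups, so the comparison is indirect, yet nothing shown points to sensitivity at this position. The expected step of a 1.0-fold lower number from compound 2 to compound 4 (0.00 log units; within the scatter) is therefore none beyond the scatter. Compound 4 is estimated at 7 nM, with a range from 2.5 nM to 25 nM.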

Compound 4, inhibition constant: 279 nM
Beside the measured number, compound 4's estimate is 40-fold (1.60 log units) below it, outside the stated range (above it).
By their numbers in this assay, from the lowest: compound 2; then compounds 1 and 3 (each within the scatter of the next); then compound 4.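

Going by these compounds alone, the ring nitrogen is not indifferent to its substituent: in this assay the change to neopentyl gives a 40-fold higher number from compound 2 to compound 4 (1.60 log units; beyond the scatter), whereas the only earlier change at this nitrogen, among the sulfoxides, gave a 1.5-fold higher number from compound 1 to compound 3 (0.18 log units; within the scatter). The group that leaves carries an aromatic ring and a hydrogen-bond acceptor, and the neopentyl that enters has neither. Nothing available explains the size of this step.

Open, from the compounds shown here alone, is whether 4-fluorobenzyl or cyclohexylmethyl on the thioether would fall near compound 2 or near compound 4, which would separate the role of the aromatic ring from that of the carbonyl.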